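This account rests on a few compounds, and the source may have more. Where it says the series, first, only, none or still open, it means among the compounds named here.

Measured so far in a functional assay on MCF7 cells (Homo sapiens) for cytotoxicity, read by MTT assay, with a stated time of 96 h; a higher number here means a weaker inhibitor, a lower number a stronger inhibitor:
- compound 1 `COc1cc(C(=O)c2cn(-c3ccccc3)cc2-c2ccc(N)cc2)cc(OC)c1OC`: 9 nM
- compound 2 `COc1cc(C(=O)c2cn(-c3ccc(C)cc3)cc2-c2ccccc2[N+](=O)[O-])cc(OC)c1OC`: 65 nM
- compound 3 `COc1cc(C(=O)c2cn(-c3ccc(C)cc3)cc2-c2cccc([N+](=O)[O-])c2)cc(OC)c1OC`: 210 nM

Compound 3, at 210 nM, has the highest number of the three. For the measured compounds named here, its nearest neighbour is compound 2, and the one measured step is a 3.2-fold higher number from compound 2 to compound 3 (0.51 log units; beyond the scatter). Compound 4 `COc1cc(C(=O)c2cn(-c3ccc(C)cc3)cc2-c2ccc(N)cc2)cc(OC)c1OC` is not yet measured: 4-aminophenyl in place of 3-nitrophenyl on an aromatic carbon, (4-aminophenyl in place of 3-nitrophenyl on an aromatic carbon). The measured step moves only the nitro group, so it bears on this change only indirectly. Closer evidence is compound 1, which carries the same 4-aminophenyl group and gives 9 nM, although it lacks the 4-methylphenyl group. Expected in this assay is a change toward a lower number, larger than the step seen so far and beyond the scatter: a 14-fold lower number from compound 3 to compound 4 (1.15 log units; beyond the scatter). For compound 4 the estimated value is 15 nM, with an expected range of 4 nM to 60 nM.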

Compound 4, half-maximal inhibitory concentration: 6 nM
Compound 4: the middle estimate sits 2.5-fold (0.40 log units) above what was measured, within the range that was stated.
By their numbers in this assay, from the lowest: compounds 4 and 1 (each within the scatter of the next); then compound 2; then compound 3.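

In this assay the 4-aminophenyl group at this position gives a large drop from either nitrophenyl group with the 4-methylphenyl group held constant (a 35-fold lower number from compound 3 to compound 4 (1.54 log units; beyond the scatter)) and (an 11-fold lower number from compound 2 to compound 4 (1.03 log units; beyond the scatter)). Methyl in place of hydrogen on the other aryl group does not separate the two amines (a 1.5-fold lower number from compound 1 to compound 4 (0.18 log units; within the scatter)). No measurement on hand accounts for these steps.

Open, going by these compounds, is whether the large step follows the amine itself or its location on the phenyl ring. A 3-aminophenyl or 4-nitrophenyl group would separate these two readings.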